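The compounds below may be only part of what the source reports. "The series", "measured", "known", "first", "only" and "open" are said of these compounds alone.

In an assay on isolated protein for inhibition of Equilibrative nucleoside transporter 1 (Homo sapiens) (on this read-out lower numbers stand for stronger inhibition and higher numbers for weaker inhibition), three compounds built on one shared core have been measured so far. Compound 1 `OC[C@H]1O[C@@H](n2cnc3c(SCc4ccccc4Cl)ncnc32)[C@H](O)[C@@H]1O` gives 117 nM. Compound 2 `OC[C@H]1O[C@@H](n2cnc3c(SCc4ccccc4I)ncnc32)[C@H](O)[C@@H]1O` gives 19.5 nM, and compound 3 `Cc1ccc(CSc2ncnc3c2ncn3[C@@H]2O[C@H](CO)[C@@H](O)[C@H]2O)cc1` gives 15.1 nM, the lowest of the three numbers; its gap to compound 2 lies within the scatter, while its gap to compound 1 lies beyond it. Compound 4 `OC[C@H]1O[C@@H](n2cnc3c(SCc4cccc(C(F)(F)F)c4)ncnc32)[C@H](O)[C@@H]1O` differs from compound 3 by 3-(trifluoromethyl)phenyl in place of 4-methylphenyl on a saturated chain carbon bound to a sulfur. Within the data shown here, two measured steps bear on this, since both swapped the aromatic group at the same place: a 7.7-fold lower number from compound 1 to compound 3 (0.89 log units; beyond the scatter) and a 1.3-fold lower number from compound 2 to compound 3 (0.11 log units; within the scatter). Such swaps have moved the number only modestly. For compound 4 a step of a 1.9-fold higher number from compound 3 to compound 4 (0.27 log units; within the scatter) is therefore expected, giving an estimated 28 nM with a range from 9 nM to 90 nM.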

Compound 4, inhibition constant: 19.1 nM
Beside the measured number, compound 4's estimate is 1.5-fold (0.17 log units) above it; the range from low to high includes it.
By their numbers in this assay, from the lowest: compounds 3, 4 and 2 (each within the scatter of the next); then compound 1.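

A step of a 1.3-fold higher number from compound 3 to compound 4 (0.10 log units; within the scatter) and one of a 1.0-fold lower number from compound 2 to compound 4 (0.01 log units; within the scatter) in this assay show that 3-(trifluoromethyl)phenyl, with more heavy atoms than 4-methylphenyl and with fluorine, holds the number at this saturated chain carbon bound to a sulfur. The step of a 6.1-fold lower number from compound 1 to compound 4 (0.79 log units; beyond the scatter) leaves compound 1 as the only one apart from the other three. Nothing measured here explains this. Every group shown at this place is a substituted phenyl, so the effect of an amine, a carboxylic acid or a longer alkyl chain there remains open.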